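The source may report more compounds than this note shows. Statements on the series, on what has been measured and on what is new or still open speak of the compounds shown alone.

Measured in an in vitro ADME assay on microsomes from liver (Homo sapiens) for metabolic stability, using NADPH; on this read-out higher numbers stand for fast clearance and lower numbers for slow clearance:

- Compound 1 `COc1ccc(OC(F)(F)F)cc1Cn1c(C(=O)NCC(C)(C)O)cc2cc(C#N)ccc21`: < 6 mL.min-1.g-1 (a limit of the assay, not a number)
- Compound 2 `CC(O)CCNC(=O)c1cc2cc(C#N)ccc2n1Cc1cccc(OC(F)(F)F)c1`: 113 mL.min-1.g-1

For the measured compounds named here, compound 2, at 113 mL.min-1.g-1, holds the only true number so far. Compound 1 and compound 2 differ in more than one place, so their two values do not isolate the effect of any single change.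

Compound 3 `N#Cc1ccc2c(c1)cc(C(=O)NCCC1(O)CCC1)n2Cc1cccc(OC(F)(F)F)c1` differs from compound 2 in one place: 1-hydroxycyclobutyl in place of 1-hydroxyethyl on a saturated chain carbon, two bonds along the chain from an amide-type nitrogen. Going by the values given here, no measured step covers this change, so the expectation starts from compound 2 at 113 mL.min-1.g-1 and remains uncertain. The expected step of a 1.6-fold lower number from compound 2 to compound 3 (0.21 log units; within the scatter) stays within the usual scatter, leaning only weakly toward slower clearance. For compound 3 the estimate in this assay is 70 mL.min-1.g-1, with an expected range of 25 mL.min-1.g-1 to 160 mL.min-1.g-1.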

Compound 3, intrinsic clearance in microsomes: 78 mL.min-1.g-1
The estimate for compound 3 lay 1.1-fold (0.05 log units) below the measured number, within the range that was stated.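

In this assay, putting 1-hydroxycyclobutyl in place of 1-hydroxyethyl on a saturated chain carbon, two bonds along the chain from an amide-type nitrogen, gives a 1.4-fold lower number from compound 2 to compound 3 (0.16 log units; within the scatter) and so stays within the usual scatter. For the compounds shown here, this is the first single-place comparison in the set, and it shows that a four-membered ring of carbon only can stand at this place with no clearance difference that can be told from repeat-measurement noise. Nothing measured here accounts for the size of this step.

As far as these compounds go, whether an amine, a carboxylic acid or a longer chain at this place would shift clearance beyond the scatter stays open. Compound 1 sits at a limit of the assay and differs from compound 2 and compound 3 in more than one place, so which of its differences goes with that limit cannot be read.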